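The compounds below may be only part of what the source reports. "The series", "measured", "known", "first", "only" and "open" are said of these compounds alone.

Measured so far in an ADME assay on MRC5 cells (Homo sapiens) for cytotoxicity, read by resazurin assay, with a stated time of 72 h; a lower number here means a stronger inhibitor, a higher number a weaker inhibitor:

Compound 1 `O=[N+]([O-])c1cn2c(n1)OC(COc1ccc(-c3ccc(F)nc3)cc1)CC2` gives > 64000 nM, a limit of the assay.
Compound 2 `O=[N+]([O-])c1cn2c(n1)OC(CN1CCC(c3ccc(F)cc3)CC1)CC2` gives > 64000 nM, also a limit.
Compound 3 `CC1(COc2ccc(-c3ccc(F)nc3)cc2)CCn2cc([N+](=O)[O-])nc2O1` gives > 64000 nM, likewise a limit.

The difference between the cores of compound 1 and compound 2 is not broken down here. Within the series one change recurs: methyl in place of hydrogen on a saturated ring carbon. This change makes a step that the two limits leave unreadable from compound 1 to compound 3; its size cannot be read, since the limit of > 64000 nM in this assay, at which 3 of the 3 values shown sit, covers every value shown.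

The same change is now applied to compound 2 to give compound 4 `CC1(CN2CCC(c3ccc(F)cc3)CC2)CCn2cc([N+](=O)[O-])nc2O1`: methyl in place of hydrogen on a saturated ring carbon. Nothing in the series points to a numbered value for this assay; all that is known is that compound 1 and compound 3 stayed at the limit across this change. The expected step from compound 2 to compound 4 is a step that the limit leaves unreadable from compound 2 to compound 4, resting on that. Compound 4 is therefore expected at 100000 nM, most probably again reported only as a limit.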

Compound 4, half-maximal inhibitory concentration: > 64000 nM
Compound 4 was reported as a limit; the forecaster's own chance of this, stated with the estimate: 85%; the middle value is on the limit's open side.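

No step can be read from compound 2 to compound 4 in this assay, since both compounds are reported only as limits: the limit of > 64000 nM in this assay, at which 4 of the 4 values shown sit. The compounds shown leave open whether methyl in place of hydrogen on a saturated ring carbon changes this read-out at all.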